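The source may report more compounds than this note shows. Statements on the series, on what has been measured and on what is new or still open speak of the compounds shown alone.

Measured compounds:
compound 1, `Cc1ccc(NC(=O)/C=C/C(=O)N2C/C(=C\c3ccc([N+](=O)[O-])cc3)C(=O)/C(=C/c3ccc([N+](=O)[O-])cc3)C2)cc1C`, 4900 nM in a functional assay on L1210 cells (Mus musculus) for cytotoxicity; a lower number here means a stronger inhibitor, a higher number a weaker inhibitor
compound 2, `Cc1ccc(NC(=O)/C=C/C(=O)N2C/C(=C\c3ccccc3)C(=O)/C(=C/c3ccccc3)C2)cc1`, 5800 nM
compound 3, `O=C(/C=C/C(=O)N1C/C(=C\c2ccc([N+](=O)[O-])cc2)C(=O)/C(=C/c2ccc([N+](=O)[O-])cc2)C1)Nc1ccc(Cl)c(Cl)c1`, 1700 nM

In this assay compound 2 stands at the high end of the three numbers: compound 1 lies within the scatter of it, while compound 3 lies beyond the scatter, on the lower side. Going by the values given here, the only step that can be read from these values runs a 2.9-fold lower number from compound 1 to compound 3 (0.46 log units; beyond the scatter), where two chlorines replace two methyls on the phenyl attached to the amide-type nitrogen.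

Compound 4, `O=C(/C=C/C(=O)N1C/C(=C\c2ccccc2)C(=O)/C(=C/c2ccccc2)C1)Nc1ccc(Cl)cc1`, is not yet measured. It differs from compound 2 in one place: chloro in place of methyl on an aromatic carbon. This is half of the change seen between compound 1 and compound 3, a single chloro for a single methyl, on a core that carries plain phenyl groups rather than nitrophenyl groups. That step was modest and beyond the scatter, so a smaller move in the same direction is expected here, possibly one that does not clear the scatter. For compound 4 the expected value in this assay is 3200 nM, within a range from 1600 nM to 6500 nM, which means an expected step of a 1.8-fold lower number from compound 2 to compound 4 (0.26 log units; within the scatter).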

Compound 4, half-maximal inhibitory concentration: 7800 nM
Compound 4: middle estimate off by 2.4-fold (0.39 log units), on the low side, and the stated range ends below it.
By their numbers in this assay, from the lowest: compound 3; then compounds 1, 2 and 4 (each within the scatter of the next).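

In this assay, 4-chlorophenyl in place of 4-methylphenyl on the amide-type nitrogen gives a 1.3-fold higher number from compound 2 to compound 4 (0.13 log units; within the scatter), so on this core with its plain phenyl groups, chloro and methyl at this position cannot be told apart. The earlier step, a 2.9-fold lower number from compound 1 to compound 3 (0.46 log units; beyond the scatter), changed 3,4-dimethylphenyl to 3,4-dichlorophenyl on a core carrying nitrophenyl groups, and the new result shows that its lower number does not carry over to a single chloro-for-methyl swap on the plain phenyl core. No measurement offered here accounts for this difference between the two steps.

The two steps differ both in how many groups on the ring change and in the core that carries them, so these compounds cannot separate those two influences, and a single swap on the nitrophenyl core or a double swap on the plain phenyl core would be needed to do so. Going by these compounds, it also remains open whether a group of another kind at this position, such as a methoxy group, an amine or a carboxylic acid, would move the number beyond the scatter.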